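Aryl variation on the shared core: a dichlorophenyl analogue

The source may report more compounds than this note shows. Statements on the series, on what has been measured and on what is new or still open speak of the compounds shown alone.

Measured so far in a functional assay on SGC-7901 cells (Homo sapiens) for antiproliferative activity, read by MTT assay, with a stated time of 72 h; on this read-out lower numbers stand for stronger inhibition and higher numbers for weaker inhibition:
compound 1, `COc1cc(-n2cnc3ccc(-c4ccc([N+](=O)[O-])cc4)cc32)cc(OC)c1OC`: 79 nM
compound 2, `COc1cc(-n2cnc3ccc(-c4cccc(Cl)c4)cc32)cc(OC)c1OC`: 1490 nM
compound 3, `COc1cc(-c2ccc3ncn(-c4cc(OC)c(OC)c(OC)c4)c3c2)cc(OC)c1OC`: > 10000 nM

Compound 1 carries the lowest of the two numbers in this assay; its nearest neighbour is compound 2, with a 19-fold higher number from compound 1 to compound 2 (1.28 log units; beyond the scatter). For compound 3 the assay gives only a limit, (the limit of > 10000 nM in this assay, at which 1 of the 3 values shown sits), and not a number.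

Compound 4, `COc1cc(-n2cnc3ccc(-c4ccc(Cl)cc4Cl)cc32)cc(OC)c1OC`, is still unmeasured. It differs from compound 1 in one place: 2,4-dichlorophenyl in place of 4-nitrophenyl on an aromatic carbon. Among the compounds with values here, the one measured step that bears on this change is the exchange of the 4-nitrophenyl for a 3-chlorophenyl, a 19-fold higher number from compound 1 to compound 2 (1.28 log units; beyond the scatter), a large rise in the number. Compound 4 likewise replaces the 4-nitrophenyl with a chlorine-bearing phenyl, so a step of comparable direction and broadly similar size is expected, a 13-fold higher number from compound 1 to compound 4 (1.10 log units; beyond the scatter), with the second chlorine leaving the size uncertain. For compound 4 the estimate in this assay is therefore 1000 nM, within a range of 200 nM to 5000 nM.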

Compound 4, half-maximal inhibitory concentration: > 10000 nM
Compound 4 gave a limit, no number (the forecaster's own chance of this, stated with the estimate: 10%); at least 10-fold (1.00 log units) between middle value and limit.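

In this assay compound 4 gives only a limit, > 10000 nM. Exchanging the 4-nitrophenyl for 2,4-dichlorophenyl gives an at least 120-fold higher number from compound 1 to compound 4 (2.10 log units; beyond the scatter), and exchanging the 3-chlorophenyl for 2,4-dichlorophenyl gives an at least 6.7-fold higher number from compound 2 to compound 4 (0.82 log units; beyond the scatter), so a chlorine-bearing phenyl at this position does not by itself keep a measurable value, and the chlorine pattern matters. Compound 3 also stands at a limit, so the step between compound 3 and compound 4 cannot be read, and the series now has two aryl groups that give no number: the limit of > 10000 nM in this assay, at which 2 of the 4 values shown sit.

Whether either chlorine of the 2,4-dichlorophenyl alone accounts for the loss stays open. Also open, as far as these compounds go, is how an aminophenyl or a phenyl carrying a carboxylic acid would behave at this position in this assay.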